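The compounds below may be only part of what the source reports. "The series", "measured", "known", "first", "only" and "open" are said of these compounds alone.

Measured in a functional assay on MCF7 cells (Homo sapiens) for antiproliferative activity, read by MTT assay, with a stated time of 72 h; a higher number here means a weaker inhibitor, a lower number a stronger inhibitor:
- compound 1 `COc1cc(-n2cnc3ccc(-c4ccc(C(C)=O)cc4)cc32)cc(OC)c1OC`: 1540 nM
- compound 2 `COc1cc(-n2cnc3ccc(-c4ccc(C)cc4F)cc32)cc(OC)c1OC`: 56 nM
- compound 3 `COc1cc(-n2cnc3ccc(-c4ccc([N+](=O)[O-])cc4)cc32)cc(OC)c1OC`: 740 nM

Compound 1 has the highest number of the three, which makes it the weakest inhibitor here. Compound 4 `COc1cc(-n2cnc3ccc(-c4cccc(Cl)c4)cc32)cc(OC)c1OC` has 3-chlorophenyl in place of 4-acetylphenyl on an aromatic carbon. Two measured steps leave the same 4-acetylphenyl group or alter it. Swapping in 2-fluoro-4-methylphenyl gives a 28-fold lower number from compound 1 to compound 2 (1.44 log units; beyond the scatter), while nitro in place of acetyl gives only a 2.1-fold lower number from compound 1 to compound 3 (0.32 log units; beyond the scatter). Neither new group contains chlorine, so these steps offer only rough guidance. Both lower the number, so a lower number is also expected in this assay, with a size within the span of those two steps. The expected change is a 7.7-fold lower number from compound 1 to compound 4 (0.89 log units; beyond the scatter). For compound 4 the estimate is 200 nM, with an expected range of 60 nM to 700 nM.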

Compound 4, half-maximal inhibitory concentration: 3120 nM
The estimate for compound 4 lay 16-fold (1.19 log units) below the measured number, and the stated range ends below it.
By their numbers in this assay, from the lowest: compound 2; then compound 3; then compound 1; then compound 4.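

In this assay, 3-chlorophenyl is the only group shown that raises the number relative to 4-acetylphenyl, with a 2.0-fold higher number from compound 1 to compound 4 (0.31 log units; beyond the scatter) as the step, so swapping this aromatic ring does not reliably give a stronger inhibitor. It also falls behind 4-nitrophenyl, with a 4.2-fold higher number from compound 3 to compound 4 (0.62 log units; beyond the scatter) as the step, and behind 2-fluoro-4-methylphenyl, with a 56-fold higher number from compound 2 to compound 4 (1.75 log units; beyond the scatter) as the step, leaving compound 4 the weakest of the four. Nothing measured here explains this order.

Still open, on these data alone, is how 4-chlorophenyl would compare with 3-chlorophenyl. It is also unclear whether 4-methylphenyl without the fluorine, or a phenyl ring bearing an amine, would match compound 2.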